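Shifting the chlorine on the triazole-borne phenyl ring

The source may hold more compounds than are shown below. What is called first, only, known or untested is meant among the compounds shown, and "the series" means these compounds.

Among the compounds with values here, the three compounds measured so far share one core and differ only in the phenyl group carried on an aromatic nitrogen. Compound 1 `Cc1ccccc1-n1cc(-c2cccc(NS(=O)(=O)c3c[nH]c(=O)[nH]c3=O)c2)nn1` gives 15300 nM in an ADME assay on L02 cells (Homo sapiens) for cytotoxicity, read by MTT assay, with a stated time of 24 h; a higher number here means that more compound is tolerated, a lower number that less compound is tolerated. Compound 2 `Cc1cccc(-n2cc(-c3cccc(NS(=O)(=O)c4c[nH]c(=O)[nH]c4=O)c3)nn2)c1` gives 28300 nM, and compound 3 `O=c1[nH]cc(S(=O)(=O)Nc2cccc(-c3cn(-c4ccccc4Cl)nn3)c2)c(=O)[nH]1` gives 11500 nM, the lowest of the three numbers. Compound 4 `O=c1[nH]cc(S(=O)(=O)Nc2cccc(-c3cn(-c4ccc(Cl)cc4)nn3)c2)c(=O)[nH]1` is not yet measured; it differs from compound 3 by 4-chlorophenyl in place of 2-chlorophenyl on an aromatic nitrogen. Within the data shown here, no measured step tests that exact change. The closest is a 1.8-fold higher number from compound 1 to compound 2 (0.27 log units; within the scatter), which also swaps one methylphenyl for another and stays within the scatter, while a 2.5-fold lower number from compound 2 to compound 3 (0.39 log units; beyond the scatter) was modest. Compound 4 is therefore expected to land near compound 3, with at most a small rise: the estimated step is a 1.6-fold higher number from compound 3 to compound 4 (0.19 log units; within the scatter), giving an expected 18000 nM with a range from 8000 nM to 40000 nM.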

Compound 4, half-maximal cytotoxic concentration: 9860 nM
Beside the measured number, compound 4's estimate is 1.8-fold (0.26 log units) above it; the range from low to high includes it.
By their numbers in this assay, from the lowest: compounds 4, 3, 1 and 2 (each within the scatter of the next, the first and the last beyond it).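

In this assay the change from 2-chlorophenyl to 4-chlorophenyl gives a 1.2-fold lower number from compound 3 to compound 4 (0.07 log units; within the scatter) and thus shows no readable effect of where the chlorine sits on this ring. The comparison with the methylphenyl compounds splits: a 1.6-fold lower number from compound 1 to compound 4 (0.19 log units; within the scatter) and stays inside the scatter, while a 2.9-fold lower number from compound 2 to compound 4 (0.46 log units; beyond the scatter) and goes beyond it, so compound 2 stands apart from both chlorophenyl compounds. Nothing shown here offers a reason for these numbers.

Still open, as far as these compounds go, is how an amine or a carboxylic acid on this phenyl ring would read in this assay as a measure of tolerance. An unsubstituted phenyl group is also left open.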